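From 4-methoxyphenyl to 4-chlorophenyl: notes on the series

This account rests on a few compounds, and the source may have more. Where it says the series, first, only, none or still open, it means among the compounds named here.

Measured so far in a functional assay on HCT-116 cells (Homo sapiens) for inhibition; on this read-out lower numbers stand for stronger inhibition and higher numbers for weaker inhibition
compound 1 `C=CC(=O)OCc1cc(=O)oc2cc(OC)c(OC)cc12` gives > 10 ug/mL
compound 2 `COc1ccc(/C=C/C(=O)OCc2cc(=O)oc3cc(OC)c(OC)cc23)cc1` gives 1.02 ug/mL

Compound 1 has only a limit (the limit of > 10 ug/mL in this assay, at which 1 of the 2 values shown sits) and no number. For the measured compounds named here, compound 2 at 1.02 ug/mL carries the only number so far.

Compound 3 `COc1cc2oc(=O)cc(COC(=O)/C=C/c3ccc(Cl)cc3)c2cc1OC` alters compound 2 at one place (chloro in place of methoxy on an aromatic carbon) with chloro in place of methoxy on an aromatic carbon, para to a large group, so that 4-methoxyphenyl becomes 4-chlorophenyl. Going by the values given here, no measured step in this assay covers this change, so only a small shift is expected, perhaps toward slightly weaker inhibition and probably not beyond the usual scatter. The expected move is a 1.5-fold higher number from compound 2 to compound 3 (0.17 log units; within the scatter) in this estimate. In this assay the estimate for compound 3 is 1.5 ug/mL with a range from 0.5 ug/mL to 5 ug/mL expected.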

Compound 3, half-maximal inhibitory concentration: > 10 ug/mL
Compound 3 gave a limit, no number; the forecaster's own chance of this, stated with the estimate: 10%; middle value at least 6.6-fold (0.82 log units) away from the limit.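

In this assay, for the compounds shown here, the change from 4-methoxyphenyl to 4-chlorophenyl gives the first readable step: an at least 9.8-fold higher number from compound 2 to compound 3 (0.99 log units; beyond the scatter). The substituent on this aromatic carbon, para to a large group, therefore has a marked bearing on the read-out, which compound 2 alone could not show. Compound 3 shares its limit with compound 1, and the step between these two compounds cannot be read: the limit of > 10 ug/mL in this assay, at which 2 of the 3 values shown sit.

As far as these compounds go, it remains open whether this step reflects the arrival of chloro or the departure of methoxy, and a hydroxyl, a dimethylamino group or a fluoro group at the same place would help to separate the two. From the compounds shown here alone, the true size of the step also remains open, since the result for compound 3 is a limit and not a number.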